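Compound 2 to Compound 3: Butoxy Gives Way to Fluoro

This account rests on a few compounds, and the source may have more. Where it says the series, first, only, none or still open, it means among the compounds named here.

Compound 1 `O=C(NNc1cccc(Cl)c1)c1ccccc1NS(=O)(=O)c1cnc(O)nc1O` gives 5520 nM
Compound 2 `CCCCOc1ccc(C(=O)NNC(=O)c2ccccc2NS(=O)(=O)c2cnc(O)nc2O)cc1` gives 5010 nM

Both were measured in a functional assay on OVCAR-3 cells (Homo sapiens) for antiproliferative activity, read by MTT assay, with a stated time of 24 h; a higher number here means a weaker inhibitor, a lower number a stronger inhibitor. Compound 2 has the lower of the two numbers, but compound 1 stands so close that the pair lies within the scatter, so no order between them can be claimed. Compound 3 `O=C(NNC(=O)c1ccccc1NS(=O)(=O)c1cnc(O)nc1O)c1ccc(F)cc1` differs from compound 2 in one place: fluoro in place of butoxy on an aromatic carbon. For the measured compounds named here, no step between measured compounds exists to guide the size of this change in this assay, so nothing beyond the scatter is expected in either direction. Compound 3 is therefore expected to give 5500 nM, between 2500 nM and 12000 nM. The step of a 1.1-fold higher number from compound 2 to compound 3 (0.04 log units; within the scatter) is estimated to fall within the scatter.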

Compound 3, half-maximal inhibitory concentration: 15100 nM
Beside the measured number, compound 3's estimate is 2.7-fold (0.44 log units) below it; measured number above the stated range.
By their numbers in this assay, from the lowest: compounds 2 and 1 (each within the scatter of the next); then compound 3.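

In this assay this place on the aromatic ring is not indifferent: fluoro in place of butoxy, para to a large group, gives a 3.0-fold higher number from compound 2 to compound 3 (0.48 log units; beyond the scatter) and so moves the number beyond the scatter. The other change, (4-fluorophenyl)carbonyl in place of 3-chlorophenyl on an amine nitrogen, gives a 2.7-fold higher number from compound 1 to compound 3 (0.44 log units; beyond the scatter) and sets compound 3 apart from both earlier compounds. Nothing available bears on why the number rises.

On these data alone, whether a methoxy or a propoxy at this place would keep the number of compound 2 stays open. So does what a chloro or an amine there would give.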